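Tert-Butyl for Chloro on Two Hydroxamic Acid Cores

The compounds below may be only part of what the source reports. "The series", "measured", "known", "first", "only" and "open" are said of these compounds alone.

Compound 1 `O=C(CCC1=CCN(CCCc2ccc(Cl)cc2)C1=O)NO` gives 2520 nM.
Compound 2 `CC(C)(C)c1ccc(CCCN2CC=C(CCC(=O)NO)C2=O)cc1` gives 2520 nM.
Compound 3 `O=C(CCC1=CCN(Cc2ccc(Cl)cc2)C1=O)NO` gives 2500 nM.

All three numbers come from a functional assay on NCI-H23 cells (Homo sapiens) for inhibition, read by sulforhodamine B assay; a lower number here means a stronger inhibitor of growth, a higher number a weaker inhibitor of growth. Compounds 1 and 2 differ in one place only, (tert-butyl in place of chloro on an aromatic carbon), and no change at the digits printed from compound 1 to compound 2 (within the scatter). Compound 3 carries the same chloro group as compound 1 but sits on a different core; the difference between the two cores is not broken down here, and the two values of compound 1 and compound 3 lie close together. Compound 4 `CC(C)(C)c1ccc(CN2CC=C(CCC(=O)NO)C2=O)cc1` has not been measured. It relates to compound 3 exactly as compound 2 relates to compound 1: tert-butyl in place of chloro on an aromatic carbon, the same change at the same place. Since the earlier step of no change at the digits printed from compound 1 to compound 2 (within the scatter) left the number where it was, the step of no change at the digits printed from compound 3 to compound 4 (within the scatter) is expected to be about as small. Compound 4 is therefore estimated at 2500 nM. Compound 4 is expected to fall between 1200 nM and 5200 nM.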

Compound 4, concentration for 50% growth inhibition: 420 nM
The estimate for compound 4 lay 6.0-fold (0.77 log units) above the measured number, and the stated range ends above it.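

Tert-butyl in place of chloro on an aromatic carbon gives, in this assay, a 6.0-fold lower number from compound 3 to compound 4 (0.77 log units; beyond the scatter). The same change therefore does not behave alike on the two cores: the same change on two cores in this assay, no change at the digits printed (within the scatter) from compound 1 to compound 2 and a 6.0-fold lower number (0.77 log units; beyond the scatter) from compound 3 to compound 4, 6.0-fold (0.77 log units) apart, beyond the scatter of two such steps. Going by these compounds alone, this shows that the result of this change on one core cannot simply be carried over to the other, but with only one pair on each core, it does not show which feature of the cores sets the two steps apart.

The compounds shown leave open how other groups at this place, such as a methoxy group or an amine, would behave on either core. They also leave open whether a longer chain would follow either of the two results.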